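A few compounds are considered here, and "the series" means these few. Any claim that something is new, unique, unknown or untested is made for them only; others in the source may bear on it.

Working notes on the series. Compound 1 `COc1ccc(Cc2cc(-c3ccc(Cl)cc3)nn(CC(=O)Nc3ccc(Br)cc3)c2=O)cc1`, compound 2 `COc1ccc(Cc2cc(-c3ccc(F)cc3)nn(CC(=O)Nc3ccc(Br)cc3)c2=O)cc1` and compound 3 `Cc1cc(Cc2cccc(F)c2)c(=O)n(CC(=O)Nc2ccc(Br)cc2)n1` have been measured; compound 4 `Cc1cc(Cc2cccc(Cl)c2)c(=O)n(CC(=O)Nc2ccc(Br)cc2)n1` has not. In a functional assay on HL-60 cells (Homo sapiens), read by calcium flux (on this read-out lower numbers stand for an effect already at smaller amounts and higher numbers for an effect only at larger amounts of compound), compound 1 reaches only the assay limit, > 50000 nM. In this assay compound 2 likewise gives only a limit, > 50000 nM. In this assay compound 3 also gives a limit, > 50000 nM. The change chloro in place of fluoro on an aromatic carbon produces the step that the two limits leave unreadable from compound 2 to compound 1. The difference between the core of compound 3 and the core of compound 2 is not broken down here. The change chloro in place of fluoro on an aromatic carbon is the same kind of change, though its place reads meta to a large group where the earlier one reads para to a large group. For compound 4 the step that the limit leaves unreadable from compound 3 to compound 4 is expected to stay unreadable because of the limit of > 50000 nM in this assay, at which 3 of the 3 values shown sit. Compound 4 is therefore estimated at 60000 nM in this assay.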

Compound 4, half-maximal effective concentration: > 50000 nM
Compound 4: no number, only a limit (the forecaster's own chance of this, stated with the estimate: 85%); the middle value does not contradict the limit.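

No step can be read from compound 3 to compound 4, since both give only a limit: the limit of > 50000 nM in this assay, at which 4 of the 4 values shown sit.

The compounds shown leave open whether chloro in place of fluoro alters the effect, and what concentration, if any, gives one.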